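A third aryl group after two level results

The compounds below may be only part of what the source reports. "The series", "measured", "known", "first", "only" and "open" are said of these compounds alone.

In a functional assay on PC-3 cells (Homo sapiens) for cytotoxicity, read by MTT assay, with a stated time of 72 h (on this read-out lower numbers stand for stronger inhibition and higher numbers for weaker inhibition), compound 1 (`COc1ccc(/C=C/C(=O)Nc2cc3c(Nc4ccc(F)c(Cl)c4)ncnc3cc2O[C@H]2CCOC2)c(OC)c1OC`) gives 7670 nM and compound 2 (`O=C(/C=C/c1ccccc1[N+](=O)[O-])Nc1cc2c(Nc3ccc(F)c(Cl)c3)ncnc2cc1O[C@H]1CCOC1`) gives 7760 nM on the same read-out. Among the measured compounds shown here, compound 2 therefore stands level with compound 1, the only other compound measured, since the two numbers lie within the scatter of each other. The next compound, compound 3 (`O=C(/C=C/c1ccc(Br)cc1)Nc1cc2c(Nc3ccc(F)c(Cl)c3)ncnc2cc1O[C@H]1CCOC1`), keeps the shared core and differs from compound 2 in one place, on a double-bonded chain carbon bound to a double-bonded chain carbon (4-bromophenyl in place of 2-nitrophenyl on a double-bonded chain carbon bound to a double-bonded chain carbon). For the measured compounds named here, one measured step bears on this change. At the same place, 2-nitrophenyl replaced 2,3,4-trimethoxyphenyl, and the result was a 1.0-fold higher number from compound 1 to compound 2 (0.01 log units; within the scatter) with no movement beyond the scatter. No measured compound carries 4-bromophenyl, so this single step is thin support, but it gives no reason to expect a real shift in this assay for the new group. The expected change is a 1.1-fold lower number from compound 2 to compound 3 (0.04 log units; within the scatter) and no step beyond the scatter is anticipated. For compound 3 the estimated value is 7000 nM (expected range 3000 nM to 16000 nM).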

Compound 3, half-maximal inhibitory concentration: 28200 nM
Compound 3: the middle estimate sits 4.0-fold (0.61 log units) below what was measured; the whole stated range lies below it.
By their numbers in this assay, from the lowest: compounds 1 and 2 (each within the scatter of the next); then compound 3.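

In this assay, the group on a double-bonded chain carbon bound to a double-bonded chain carbon proves able to move the number, which the level pair of compound 1 and compound 2 could not show: 4-bromophenyl gives a real rise against 2-nitrophenyl (a 3.6-fold higher number from compound 2 to compound 3 (0.56 log units; beyond the scatter)) and an equal-sized rise against 2,3,4-trimethoxyphenyl (a 3.7-fold higher number from compound 1 to compound 3 (0.57 log units; beyond the scatter)). The two earlier aryl groups, though they share no substituent, therefore stand together, and compound 3, with its steps to both beyond the scatter, is the weakest of the three on this read-out, so the level first step did not mean that any aryl group is tolerated here. No information is available on why 4-bromophenyl behaves differently from the other two groups.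

The three compounds cannot separate the effect of the bromine itself from that of where it sits on the ring, since 4-bromophenyl differs from the other two groups in both respects. Going by these compounds, whether a 2-bromophenyl, a 4-nitrophenyl or an unsubstituted phenyl would stand with compound 1 and compound 2 or with compound 3 remains open.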